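Ethoxy on the Phenyl: An Expectation for Compound 3

The source may hold more compounds than are shown below. What is called first, only, known or untested is meant among the compounds shown, and "the series" means these compounds.

compound 1 `O=C1C2ON=C(c3cn(-c4ccccc4)nc3-c3ccccc3)C2C(=O)N1c1ccccc1` 30.6%
compound 2 `CN1C(=O)C2ON=C(c3cn(-c4ccccc4)nc3-c3ccccc3)C2C1=O` 1.17%

In a functional assay on the whole organism (Abdomen, strain Swiss albino) with Mus musculus as the target, with stated times of 10 min and 5 min, at a dose of 15 mg/kg by the oral route (on this read-out higher numbers stand for a stronger effect at the one dose given and lower numbers for a weaker effect), compound 1 gives 30.6%, the higher of the two numbers. Compound 2 gives 1.17%, with a number 29.4 percentage points lower from compound 1 to compound 2 (beyond the scatter). Compound 3 `CCOc1ccc(-c2nn(-c3ccccc3)cc2C2=NOC3C(=O)N(c4ccccc4)C(=O)C23)cc1` differs from compound 1 by ethoxy in place of hydrogen on an aromatic carbon. Among the compounds with values here, the one measured step concerns an amide-type ring nitrogen, not an aromatic carbon, so no measured step bears on the change to compound 3. The step from compound 1 to compound 3 is therefore expected to be a number 0.6 percentage points lower from compound 1 to compound 3 (within the scatter), not beyond the scatter. Compound 3 is estimated at 30%, between 8% and 55%.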

Compound 3, a percentage reported as activity, at one dose (the size of the read-out at that dose, not a potency): 12.2%
Compound 3: the middle estimate sits 17.8 percentage points above what was measured, and the stated range covers the measured number.
By their numbers in this assay, from the lowest: compound 2; then compound 3; then compound 1.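

Ethoxy in place of hydrogen on an aromatic carbon, para to a large group, gives a number 18.4 percentage points lower from compound 1 to compound 3 (beyond the scatter) in this assay at the one dose given. The effect therefore responds not only to the group on the amide-type ring nitrogen but also to this place on the aromatic ring. No measurement at hand explains this drop.

As far as these compounds go, whether a fluorine, a hydroxyl or a carboxylic acid on this carbon would keep the effect of compound 1 stays open. A single-dose read-out also leaves potency open.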